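The source may report more compounds than this note shows. Statements on the series, on what has been measured and on what is new or still open speak of the compounds shown alone.

Measured in an assay on HEK293 cells for displacement of a labelled ligand from NPC1-like intracellular cholesterol transporter 1 (Homo sapiens); on this read-out higher numbers stand for weaker inhibition and lower numbers for stronger inhibition:
- compound 1 `CCOC(=O)C1CCN(C(=O)CN2CN(c3ccccc3)C3(CCN(C(=O)c4ccc(C5CCCCC5)cc4)CC3)C2=O)CC1` gives 900 nM
- compound 2 `CC(C)(C)c1ccc(C(=O)N2CCC3(CC2)C(=O)N(CC(=O)NCCCCCNS(C)(=O)=O)CN3c2ccccc2)cc1` gives 5500 nM
- compound 3 `CC(C)(C)OC(=O)NC1CCN(C(=O)CN2CN(c3ccccc3)C3(CCN(C(=O)c4ccc(C5CCCCC5)cc4)CC3)C2=O)CC1` gives 4800 nM

Compound 2 stands at the highest number of the three in this assay. Its nearest neighbour is compound 3, within the scatter of repeated measurement, while compound 1 is the furthest from it, beyond the scatter.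

Compound 4 `CC(C)(C)c1ccc(C(=O)N2CCC3(CC2)C(=O)N(CC(=O)NCN)CN3c2ccccc2)cc1` has not been measured. The change from compound 2 to compound 4 is amino in place of 4-(methanesulfonamido)butyl on a saturated chain carbon bound to an amide-type nitrogen.

Going by the values given here, the one step measured so far with a single point of difference, a 5.3-fold higher number from compound 1 to compound 3 (0.73 log units; beyond the scatter), concerns the group on a saturated ring carbon in a different part of the molecule and does not touch the chain altered here. Among the compounds with values here, no measured step reports what removing the 4-(methanesulfonamido)butyl group at this position does, so the direction for compound 4 is not anchored by any comparison in hand. The working expectation for compound 4 in this assay is a number near that of compound 2, the estimated step being a 1.5-fold higher number from compound 2 to compound 4 (0.16 log units; within the scatter), with a wide range on either side. Compound 4 is therefore estimated at 8000 nM, between 2500 nM and 25000 nM.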

Compound 4, half-maximal inhibitory concentration: 26500 nM
Compound 4: the middle estimate sits 3.3-fold (0.52 log units) below what was measured; the whole stated range lies below it.
By their numbers in this assay, from the lowest: compound 1; then compounds 3 and 2 (each within the scatter of the next); then compound 4.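

Amino in place of 4-(methanesulfonamido)butyl on a saturated chain carbon bound to an amide-type nitrogen gives a 4.8-fold higher number from compound 2 to compound 4 (0.68 log units; beyond the scatter) in this assay and is the first measured change at this position. The number therefore responds to what this chain carries, with the longer chain ending in methanesulfonamide going with the lower number, although one pair sets no trend for other groups. No measurement at hand offers an explanation for this step.

As far as these compounds go, this pair changes chain length and the end group together, so the contribution of each remains open. A 5-aminopentyl chain, or a methanesulfonamide on a chain as short as aminomethyl, would separate the two, and a carboxylic acid at the chain end would test a different end group.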